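One Methoxy Group Added, One Measurement Awaited

The source may hold more compounds than are shown below. What is called first, only, known or untested is meant among the compounds shown, and "the series" means these compounds.

Compound 1, `CO/C(=C\c1ccccc1)C(=O)Nc1ccccc1`: 15200 nM
Compound 2, `CO/C(=C\c1ccccc1)C(=O)Nc1ccc(Cl)cc1`: 17000 nM

Of the compounds shown here, two have been measured in a functional assay on cells (Splenocyte, Mus musculus, strain BALB/c) for inhibition, read by MTT assay, with a stated time of 48 h; a lower number here means a stronger inhibitor, a higher number a weaker inhibitor. Within the data shown here, compound 1 gives 15200 nM and compound 2 gives 17000 nM; the single step between them, a 1.1-fold higher number from compound 1 to compound 2 (0.05 log units; within the scatter), falls within the scatter, so compound 2 holds the highest of the two numbers without standing apart from compound 1. Compound 3, `CO/C(=C\c1ccc(OC)cc1)C(=O)Nc1ccc(Cl)cc1`, differs from compound 2 by methoxy in place of hydrogen on an aromatic carbon. Among the measured compounds shown here, no measured step concerns this change, and the only step available, a 1.1-fold higher number from compound 1 to compound 2 (0.05 log units; within the scatter), touches a different position and lies within the scatter. There is therefore no basis to expect a shift beyond the scatter in this assay, in either direction. Compound 3 is expected to give about 14000 nM, between 5000 nM and 40000 nM. That estimate corresponds to an expected step of a 1.2-fold lower number from compound 2 to compound 3 (0.08 log units; within the scatter).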

Compound 3, half-maximal inhibitory concentration: 14700 nM
Compound 3: middle estimate off by 1.1-fold (0.02 log units), on the low side; the measured number falls inside the stated range.
By their numbers in this assay, from the lowest: compounds 3, 1 and 2 (each within the scatter of the next).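

Among these compounds, the step of a 1.2-fold lower number from compound 2 to compound 3 (0.06 log units; within the scatter) in this assay is the only reading at this place, an aromatic carbon para to a large group, and it shows that methoxy in place of hydrogen leaves the number within the scatter. This place thus joins the one carrying the chloro in compound 2: neither change shown so far moves the number beyond the scatter. No evidence is available that bears on this result.

The compounds shown leave open whether an amine or a carboxylic acid at the same place would shift the number beyond the scatter. They also leave open whether methoxy would give a similar result on the core of compound 1, without the chloro.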